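Nitro substitution on the isatin ring of a coumarin-triazole hybrid

This account rests on a few compounds, and the source may have more. Where it says the series, first, only, none or still open, it means among the compounds named here.

Measured compounds:
compound 1 `COc1ccc2c(c1)C(=O)C(=O)N2CCCCCn1cc(COc2cc(=O)oc3ccccc23)nn1` gives 30%
compound 2 `O=C1C(=O)N(CCCCCn2cc(COc3cc(=O)oc4ccccc34)nn2)c2ccccc21` gives 69%

In a functional assay on THP-1 cells (Homo sapiens) for inhibition, read by sulforhodamine B assay, with a stated time of 48 h, tested at 50 uM (a higher number here means more inhibition of growth at the concentration tested, a lower number less inhibition of growth), compound 2 stands highest of the two, with compound 1 a number lower, as the step of a number 39 percentage points higher from compound 1 to compound 2 (beyond the scatter) shows. Compound 3 `O=C1C(=O)N(CCCCCn2cc(COc3cc(=O)oc4ccccc34)nn2)c2ccc([N+](=O)[O-])cc21` differs from compound 2 by nitro in place of hydrogen on an aromatic carbon. Going by the values given here, the only measured step, from hydrogen in place of methoxy, concerns a different group on the same aromatic ring and was large, but no step shows a nitro group entering. Compound 3 is therefore expected to lie near compound 2, with a wide range, a step of a number 14 percentage points lower from compound 2 to compound 3 (beyond the scatter), giving an estimate of 55% (range 25% to 85%).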

Compound 3, percent growth inhibition at one concentration: 37%
For compound 3 the middle estimate is 18 percentage points above the measured one; measured number inside the range.
By their numbers in this assay, from the lowest: compounds 1 and 3 (each within the scatter of the next); then compound 2.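

In this assay, a nitro group on this aromatic carbon gives a number 32 percentage points lower from compound 2 to compound 3 (beyond the scatter) and so shows a second group, after methoxy, that goes with less growth inhibition than hydrogen. The two substituents do not separate, with a number 7 percentage points higher from compound 1 to compound 3 (within the scatter) and thus no order between them. Nothing available here explains this result.

As far as these compounds go, whether any group at this carbon lowers the inhibition remains open, as an amine, a fluorine atom or a carboxylic acid there could show. From the compounds shown here alone, how a shorter or longer chain would alter the nitro result also remains open.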